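Replacing an amide by a urea on the methoxy core

A few compounds are considered here, and "the series" means these few. Any claim that something is new, unique, unknown or untested is made for them only; others in the source may bear on it.

Compound 1 `COc1cc(-c2nn(-c3cccc(NC(=O)c4ccc(Cl)c(C(F)(F)F)c4)c3)cc2-c2ccncc2)ccc1Cl` is an amide. In a functional assay on U-251 cells (Homo sapiens) for inhibition, read by sulforhodamine B assay, with a stated time of 48 h (a lower number here means a stronger inhibitor of growth, a higher number a weaker inhibitor of growth), compound 1 gives only a limit, > 32500 nM, and this is the limit of > 32500 nM in this assay, at which 1 of the 3 values shown sits. Two ureas built on a hydroxy core were also measured: compound 2 `O=C(Nc1cccc(-n2cc(-c3ccncc3)c(-c3ccc(Cl)c(O)c3)n2)c1)Nc1cc(C(F)(F)F)cc(C(F)(F)F)c1` gives 1170 nM in this assay, and compound 3 `O=C(Nc1cccc(-n2cc(-c3ccncc3)c(-c3ccc(Cl)c(O)c3)n2)c1)Nc1ccc(Cl)c(C(F)(F)F)c1` gives 1230 nM. Compound 4 `COc1cc(-c2nn(-c3cccc(NC(=O)Nc4ccc(Cl)c(Cl)c4)c3)cc2-c2ccncc2)ccc1Cl` keeps the core of compound 1 and differs from it in one place: (3,4-dichlorophenyl)amino in place of 4-chloro-3-(trifluoromethyl)phenyl on a carbonyl carbon. Because compound 3 gives 1230 nM with a urea carrying a closely related ring, a step toward stronger growth inhibition beyond the usual scatter is expected, and compound 4 is estimated at 5000 nM in this assay, within 1500 nM to 20000 nM, meaning an expected step of an at least 6.5-fold lower number from compound 1 to compound 4 (0.81 log units; beyond the scatter).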

Compound 4, concentration for total growth inhibition: 2470 nM
Estimate against measurement, compound 4: 2.0-fold (0.31 log units) above; the range from low to high includes it.
By their numbers in this assay, from the lowest: compounds 2, 3 and 4 (each within the scatter of the next, the first and the last beyond it). At a limit, above all of these: compound 1.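

On the core of compound 1, the swap of (3,4-dichlorophenyl)amino for 4-chloro-3-(trifluoromethyl)phenyl on a carbonyl carbon gives an at least 13-fold lower number from compound 1 to compound 4 (1.11 log units; beyond the scatter) in this assay. That size is only a floor, since compound 1 stands at a limit and not at a true number: the limit of > 32500 nM in this assay, at which 1 of the 4 values shown sits. The swap turns the amide into a urea and also trades trifluoromethyl for chloro, and this one step does not separate the two.

Still open, from the compounds shown here alone, is how the amide with a 3,4-dichlorophenyl ring would read on this core. Also open, going by these compounds, is whether a urea ending in a butyl chain instead of an aromatic ring would keep growth inhibition.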